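Swapping methylsulfonyl for piperazine on the shared core

The compounds below may be only part of what the source reports. "The series", "measured", "known", "first", "only" and "open" are said of these compounds alone.

Among the compounds with values here, compound 1 `CC(C)c1n[nH]c2c(NCc3ccc(-c4ccccn4)cc3)nc(S(C)(=O)=O)nc12` stands highest of the two numbers measured so far; in a functional assay on HCT-116 cells (Homo sapiens) for cytotoxicity, read by fluorescence, with a stated time of 72 h (a lower number here means a stronger inhibitor, a higher number a weaker inhibitor), compound 1 gives 1140 nM. Compound 2 `CC(C)c1n[nH]c2c(NCc3ccc(-c4ccccn4)cc3)nc(N[C@@H]3CCCC[C@H]3N)nc12` gives 427 nM, a step of a 2.7-fold lower number from compound 1 to compound 2 (0.43 log units; beyond the scatter). Compound 3 `CC(C)c1n[nH]c2c(NCc3ccc(-c4ccccn4)cc3)nc(N3CCNCC3)nc12` differs from compound 1 by piperazin-1-yl in place of methylsulfonyl on an aromatic carbon. Within the data shown here, the only step that bears on this change is the one from compound 1 to compound 2, where the methylsulfonyl was likewise replaced by a nitrogen-bearing group, and that step was modest. A step of similar size and direction is therefore expected, a 2.3-fold lower number from compound 1 to compound 3 (0.36 log units; beyond the scatter). Compound 3 is thus estimated at 500 nM, within a range from 200 nM to 1300 nM.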

Compound 3, half-maximal inhibitory concentration: 88 nM
Estimate against measurement, compound 3: 5.7-fold (0.75 log units) above; measured number below the stated range.
By their numbers in this assay, from the lowest: compound 3; then compound 2; then compound 1.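

Piperazin-1-yl in place of methylsulfonyl gives a 13-fold lower number from compound 1 to compound 3 (1.11 log units; beyond the scatter), and piperazin-1-yl in place of (2-aminocyclohexyl)amino gives a 4.9-fold lower number from compound 2 to compound 3 (0.69 log units; beyond the scatter). The two nitrogen-bearing groups at this place therefore differ beyond the scatter, so the number depends on which group enters, not only on methylsulfonyl leaving. Nothing available explains this difference.

Still open, going by these compounds, is how morpholin-4-yl, with an oxygen in place of the second ring nitrogen, or 4-methylpiperazin-1-yl would behave at this place. Either would show whether the ring's free amine matters.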